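Cyclopropylmethoxy to methoxy: expected effect on half-life

This account rests on a few compounds, and the source may have more. Where it says the series, first, only, none or still open, it means among the compounds named here.

- compound 1 `CN1Cc2cc(ccc2S(=O)(=O)C2CC2)NC(=O)CCc2cc(ccc2OCC2CC2)[C@@H](Nc2ccc3c(N)ncc(F)c3c2)C1=O` half-life (0.383 h)
- compound 2 `COc1ccc2cc1[C@H](C)CN(C)C(=O)Nc1ccc(S(=O)(=O)C3CC3)c(c1)CN(C)C(=O)C2Nc1ccc2c(N)ncc(F)c2c1` half-life (0.1 h)

In an ADME assay on liver (Homo sapiens) for metabolic stability, using microsomes (on this read-out lower numbers stand for a shorter-lived compound and higher numbers for a longer-lived compound), compound 1 has the higher of the two numbers (0.383 h), and its gap to compound 2 (0.1 h) lies beyond the usual scatter of repeat measurements. Going by the values given here, no two measured compounds differ in only one place, so the data show no single change on its own.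

Compound 3 `COc1ccc2cc1CCC(=O)Nc1ccc(S(=O)(=O)C3CC3)c(c1)CN(C)C(=O)[C@@H]2Nc1ccc2c(N)ncc(F)c2c1` is not yet measured. It differs from compound 1 in one place, with hydrogen in place of cyclopropyl on a saturated chain carbon bound to an oxygen on an aromatic ring, so cyclopropylmethoxy becomes methoxy. Among the compounds with values here, with no measured precedent, the expectation in this assay is for no step beyond the scatter, and an expected 1.3-fold lower number from compound 1 to compound 3 (0.11 log units; within the scatter) would fit that. For compound 3 the estimated half-life is 0.3 h (expected range 0.12 h to 0.7 h).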

Compound 3, half-life: 0.233 h
The estimate for compound 3 lay 1.3-fold (0.11 log units) above the measured number; low and high end bracket the measured number.
By their numbers in this assay, from the lowest: compound 2; then compounds 3 and 1 (each within the scatter of the next).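

In this assay, going by these compounds alone, the change from cyclopropylmethoxy to methoxy gives a 1.6-fold lower number from compound 1 to compound 3 (0.22 log units; within the scatter) and is the first single change that can be read at this place, a saturated chain carbon bound to an oxygen on an aromatic ring. Removing the cyclopropyl ring with its 3 heavy atoms therefore leaves the half-life within the usual scatter of repeat measurements, and compound 1 and compound 3 cannot be told apart on this read-out. The data shown offer no measured explanation for this result.

Going by these compounds, one step at one place gives no trend, so it stays open whether ethoxy, a longer chain, or a hydroxyl group at this place would give a half-life beyond that scatter. Compound 2 differs from compound 3 in more than one place, so it cannot settle that question.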